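The source may report more compounds than this note shows. Statements on the series, on what has been measured and on what is new or still open speak of the compounds shown alone.

Working notes on the series in an assay on HEK293 cells for inhibition of sodium channel protein type 3 subunit alpha (Homo sapiens), read by electrophysiology, with a stated time of 3.5 min; a higher number here means a weaker inhibitor, a lower number a stronger inhibitor. Compound 2 `NC(=O)[C@@H]1CC[C@H](c2ccc(OCc3ccccc3)cc2)N1` carries a benzyl group on the ring oxygen; in this assay compound 2 gives > 63000 nM, a limit of the assay and not a number. Compound 3 `N#Cc1ccc(COc2ccc([C@H]3CC[C@@H](C(N)=O)N3)cc2)cc1` differs by cyano in place of hydrogen on an aromatic carbon; in this assay compound 3 likewise gives > 63000 nM, again a limit. The step that the two limits leave unreadable from compound 2 to compound 3 therefore cannot be read. Compound 1 `N#Cc1ccccc1Oc1ccc([C@H]2CC[C@@H](C(N)=O)N2)cc1` carries phenyl on that oxygen with a nitrile in addition; in this assay compound 1 gives > 100000 nM, also a limit. Compound 2 thus stands at a limit, as do both others, per the limit of > 63000 nM in this assay, at which 2 of the 3 values shown sit, and (the limit of > 100000 nM in this assay, at which 1 of the 3 values shown sits). Compound 4 `NC(=O)[C@@H]1CC[C@H](c2ccc(Oc3ccccc3)cc2)N1` differs from compound 2 by phenyl in place of benzyl on an oxygen on an aromatic ring. Among the compounds with values here, no measured step bears on this change; compound 1, the nearest in structure, shows only a limit. The expected step is a step that the limit leaves unreadable from compound 2 to compound 4, none beyond the scatter, with a further limit likely. Compound 4 is estimated at 100000 nM, range 40000 nM to 300000 nM.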

Compound 4, half-maximal inhibitory concentration: 100000 nM
Compound 4: middle estimate and measured number agree at the digits printed; low and high end bracket the measured number.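

In this assay, within the data shown here, compound 4 gives 100000 nM, the first number and not a limit, and hydrogen in place of cyano on an aromatic carbon gives a number no higher from compound 1 to compound 4 (the limit leaves the size open). The step from compound 2 to compound 4 cannot be read, so the change from benzyl to phenyl has no size. Compound 2 and compound 3 remain limits of the assay: the limit of > 63000 nM in this assay, at which 2 of the 4 values shown sit.

The compounds shown leave open whether any group on this oxygen gives a value clearly lower than that of compound 4. An amine or a carboxylic acid on the phenyl, or a longer chain in place of benzyl, would bear on that question.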